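From a Free Acid to Its Butyl Ester

The compounds below may be only part of what the source reports. "The series", "measured", "known", "first", "only" and "open" are said of these compounds alone.

Compound 1 `O=C(O)c1cc(N2C(=O)C3=C(CCCC3)C2=O)c(F)cc1Cl` and compound 2 `O=C(O)c1cc(N2C(=O)C3=C(CCCC3)C2=O)ccc1Cl` share one core and differ only by hydrogen in place of fluoro on an aromatic carbon. In a functional assay on the whole organism for inhibition, with Scenedesmus acutus as the target (on this read-out higher numbers stand for weaker inhibition and lower numbers for stronger inhibition), compound 1 gives 1000 nM. Compound 2 reaches only a limit of this assay, > 100000 nM, with no number behind it. Going by the values given here, the single measured step, an at least 100-fold higher number from compound 1 to compound 2 (2.00 log units; beyond the scatter), concerns the fluoro and nothing else. Of the two values shown, compound 2 thus stands at the weak end, at the limit (the limit of > 100000 nM in this assay, at which 1 of the 2 values shown sits).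

Compound 3 `CCCCOC(=O)c1cc(N2C(=O)C3=C(CCCC3)C2=O)ccc1Cl` is the butyl ester of compound 2: butyl in place of hydrogen on an oxygen next to a carbonyl group. Read one bond further out, the carboxy becomes butoxycarbonyl. Among the compounds with values here, no measured step touches this change; the step from fluoro to hydrogen says nothing about an ester at the acid, so the data give no direction for this assay. Compound 3 is therefore expected to remain near the limit, with an expected step of a number no higher from compound 2 to compound 3 (the limit leaves the size open). The estimate for compound 3 is 100000 nM, between 10000 nM and 300000 nM.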

Compound 3, half-maximal inhibitory concentration: 6310 nM
The estimate for compound 3 lay 16-fold (1.20 log units) above the measured number, and the stated range ends above it.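

In this assay, going by these compounds alone, the change from carboxy to butoxycarbonyl gives an at least 15-fold lower number from compound 2 to compound 3 (1.19 log units; beyond the scatter), so the acid group, which no earlier step touched, can move the read-out towards stronger inhibition on its own. The earlier compounds shown here showed only that removing the fluoro took the read-out to a limit. Compound 3, which also lacks the fluoro, gives a measured 6310 nM. So the absence of the fluoro does not by itself hold a compound of this series at the limit. The value of compound 2 is a limit and not a number, which leaves the true size of this step open: the limit of > 100000 nM in this assay, at which 1 of the 3 values shown sits.

From the compounds shown here alone, how far the result belongs to butyl in particular remains open, as a methyl ester, an ester with a longer chain, or an amide in place of the butoxy could each read differently. Also open, going by these compounds, is what a butyl ester would give on the fluoro-bearing core of compound 1, and so whether the fluoro and the ester add up, stand in for each other, or do neither.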